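The source may hold more compounds than are shown below. What is called first, only, known or untested is meant among the compounds shown, and "the series" means these compounds.

Of the compounds shown here, two built on a shared core have been measured in an ADME assay on microsomes from liver (Homo sapiens) for metabolic stability, read by LC-MS, with NADPH named in the record, with a stated time of 60 min, tested at 1 uM, in the absence of a further agent; a lower number here means that less of the compound is left, a higher number that more of the compound is left. Compound 1, `CC(=O)N[C@@H]1CCN(c2cc(C)nn3c(-c4cccs4)c(C)nc23)C1`, is the simpler of the two. In this assay compound 1 gives > 95%, which is a limit of the assay rather than a number. Compound 2, `COc1ccc(-c2c(C)nc3c(N4CC[C@@H](NC(=O)COc5ccccc5)C4)cc(C)nn23)cc1OC`, carries a larger group on its amine nitrogen. In this assay compound 2 gives > 95%, again a limit and not a number. Both values therefore sit at the same limit, as the limit of > 95% in this assay, at which 2 of the 2 values shown sit, shows, so compound 2 stands where compound 1 stands. Compound 3, `COc1ccc(-c2c(C)nc3c(N4CC[C@@H](NS(=O)(=O)c5ccccc5)C4)cc(C)nn23)cc1OC`, has not yet been measured. It differs from compound 2 in one place: phenylsulfonyl in place of (phenoxymethyl)carbonyl on an amine nitrogen. Going by the values given here, no step between measured compounds exists to show how large such a change is, so the shift is expected to stay within the usual scatter a number at least 1 percentage points lower from compound 2 to compound 3 (that floor lies within the scatter). Compound 3 is estimated at 94%, within a range from 80% to 99%.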

Compound 3, percent of the compound remaining: > 95%
Compound 3 was reported as a limit; the forecaster's own chance of this, stated with the estimate: 60%; at least 1 percentage points between middle value and limit.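

In this assay compound 3 gives > 95%, a limit of the assay and not a number. No size can be read for the change from compound 2 to compound 3, as all values share one limit: the limit of > 95% in this assay, at which 3 of the 3 values shown sit. As far as these compounds go, whether phenylsulfonyl and (phenoxymethyl)carbonyl differ at all in the percent of compound remaining stays open.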